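The compounds below may be only part of what the source reports. "The series", "measured", "known", "first", "only" and "open" are said of these compounds alone.

Measured so far in a physicochemical assay for solubility, at pH 7; on this read-out higher numbers stand for higher solubility and lower numbers for lower solubility:
- compound 1 `CC(=O)N1CCN(C(=O)N2Cc3c(NC(=O)c4ccc(F)cc4)n[nH]c3C2(C)C)CC1` gives > 225000 nM (a limit, not a number)
- compound 2 `CC(C)(C)C(=O)N1Cc2c(NC(=O)c3ccc(F)cc3)n[nH]c2C1(C)C` gives 235000 nM

Among the measured compounds shown here, compound 2 holds the only true number (235000 nM). For compound 1 the reading is a limit (the limit of > 225000 nM in this assay, at which 1 of the 2 values shown sits).

Compound 3 `CC(=O)N1CCC(C(=O)N2Cc3c(NC(=O)c4ccc(F)cc4)n[nH]c3C2(C)C)CC1` has not yet been measured. It differs from compound 2 by one change (1-acetylpiperidin-4-yl in place of tert-butyl on a carbonyl carbon): 1-acetylpiperidin-4-yl in place of tert-butyl on a carbonyl carbon, the same place that varies between the two measured compounds. For the measured compounds named here, only one measured step bears on this change (a step that the limit leaves unreadable from compound 1 to compound 2), and it has tert-butyl in place of 4-acetylpiperazin-1-yl. That step offers no size to carry over, so no step beyond the usual scatter is expected in this assay, in either direction. The expected step is small (a 1.0-fold lower number from compound 2 to compound 3 (0.02 log units; within the scatter)). The series holds no readable step that would argue for a larger one. The estimate for compound 3 is 225000 nM with an expected range from 120000 nM to 320000 nM in this read-out.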

Compound 3, solubility: 204000 nM
Compound 3: the middle estimate sits 1.1-fold (0.04 log units) above what was measured, within the range that was stated.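

In this assay, this place on a carbonyl carbon whose other neighbours are an amide-type nitrogen in a ring now has a step with a true number at both ends, and it stays within the scatter (a 1.2-fold lower number from compound 2 to compound 3 (0.06 log units; within the scatter)). The exchange of tert-butyl, with no ring and no hydrogen-bond acceptor, for 1-acetylpiperidin-4-yl, with its six-membered non-aromatic ring and one hydrogen-bond acceptor, therefore leaves no readable mark on this read-out, and the comparison of the two acetyl-bearing rings adds only a floor that also lies within the scatter (an at least 1.1-fold lower number from compound 1 to compound 3 (0.04 log units; that floor lies within the scatter)). That floor has no true size, as compound 1 carries a limit and not a number: the limit of > 225000 nM in this assay, at which 1 of the 3 values shown sits.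

Open, on these data alone, is whether a free amine or a carboxylic acid on this carbonyl carbon, in place of 1-acetylpiperidin-4-yl, would give a step beyond the scatter in this assay. Also open is what a change elsewhere in the shared core would do, as the compounds shown vary at this one place only.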